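Halogenated aryl groups on a shared antiproliferative core

The source may report more compounds than this note shows. Statements on the series, on what has been measured and on what is new or still open speak of the compounds shown alone.

The measured compounds are few. Compound 1 `N#CC1=C(N)Oc2c(N)cc3nc4ccccc4nc3c2C12C(=O)N(Cc1cnnn1-c1ccc(Cl)cc1)c1ccccc12` reaches only a limit of the assay, > 50000 nM. Compound 2 `CCOc1ccc(-n2nncc2CN2C(=O)C3(C(C#N)=C(N)Oc4c(N)cc5nc6ccccc6nc5c43)c3ccccc32)cc1` gives 26800 nM. Compound 3 `Cc1ccc(-n2nncc2CN2C(=O)C3(C(C#N)=C(N)Oc4c(N)cc5nc6ccccc6nc5c43)c3ccccc32)cc1C` also reaches only a limit, > 50000 nM.

In a functional assay on MCF7 cells (Homo sapiens) for antiproliferative activity, read by MTT assay, with a stated time of 48 h (on this read-out higher numbers stand for weaker inhibition and lower numbers for stronger inhibition), compound 3 therefore stands at a limit and no number is known for it. Two of the three values sit at that same ceiling, as the evidence shows: the limit of > 50000 nM in this assay, at which 2 of the 3 values shown sit. The step of an at least 1.8-fold higher number from compound 2 to compound 3 (0.27 log units; that floor lies within the scatter) is readable only as a floor, and the step that the two limits leave unreadable from compound 1 to compound 3 cannot be read at all. Within the data shown here, the one numbered value belongs to compound 2, which carries the 4-ethoxyphenyl group, while the 4-chlorophenyl compound 1 and the 3,4-dimethylphenyl compound 3 sit at the limit.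

Compound 4 `N#CC1=C(N)Oc2c(N)cc3nc4ccccc4nc3c2C12C(=O)N(Cc1cnnn1-c1ccc(F)c(Cl)c1)c1ccccc12` differs from compound 3 in one place: 3-chloro-4-fluorophenyl in place of 3,4-dimethylphenyl on an aromatic nitrogen. The 3-chloro-4-fluorophenyl group carries halogens, as the 4-chlorophenyl group of compound 1 does, and compound 1 gave no number. Among the measured compounds shown here, no measured step points to a readable gain, so compound 4 is expected to remain near the limit, with an expected step that the limit leaves unreadable from compound 3 to compound 4 that is not beyond the scatter. Compound 4 is estimated at 60000 nM, between 25000 nM and 150000 nM.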

Compound 4, half-maximal inhibitory concentration: 17800 nM
Compound 4: middle estimate off by 3.4-fold (0.53 log units), on the high side; measured number below the stated range.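

In this assay the aryl group on the aromatic nitrogen can carry halogens and still bring a compound off the limit: the 3-chloro-4-fluorophenyl group gives an at least 2.8-fold lower number from compound 3 to compound 4 (0.44 log units; beyond the scatter) and also an at least 2.8-fold lower number from compound 1 to compound 4 (0.44 log units; beyond the scatter). The 4-chlorophenyl group of compound 1 therefore does not speak for all halogenated aryl groups at this position. Against the 4-ethoxyphenyl group the same change gives a 1.5-fold lower number from compound 2 to compound 4 (0.18 log units; within the scatter), so compound 2 and compound 4 cannot be ordered, and two compounds still stand at the ceiling: the limit of > 50000 nM in this assay, at which 2 of the 4 values shown sit.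

The compounds shown leave open whether the chlorine, the fluorine or the two together account for the readable value of compound 4. They also leave open how an amine or a carboxylic acid on the same aryl ring would read.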